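The compounds below may be only part of what the source reports. "The series", "measured", "known", "first", "only" and "open" are said of these compounds alone.

Working notes on the series.

Compound 1 `CCCCCCCC/C=C\CCCCCCCC(=O)N[C@H]1[C@@H](OCCCCCCCC)O[C@H](CO)[C@@H](O)[C@@H]1O` in a functional assay on C6 cells (Rattus norvegicus), read by thymidine incorporation (a lower number here means a stronger inhibitor, a higher number a weaker inhibitor), gives 12 uM. Compound 2 `CCCCCCCC/C=C\CCCCCCCC(=O)N[C@H]1[C@@H](OCCCCCCCC)O[C@H](COCC(CO)(CO)CO)[C@@H](O)[C@@H]1O` in this assay gives 11.9 uM; the step of a 1.0-fold lower number from compound 1 to compound 2 (0.00 log units; within the scatter) is the only one so far, and the two numbers for compound 1 and compound 2 lie within the scatter of each other, so on the numbers shown compound 2 stands at the same level as compound 1 rather than apart from it.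

Compound 3 `CCCCCCCC/C=C\CCCCCCCC(=O)N[C@H]1[C@@H](OCCCCCCCC)O[C@H](COS(=O)(=O)O)[C@@H](O)[C@@H]1O` is the next member. Its change from compound 2 is sulfo in place of 3-hydroxy-2,2-bis(hydroxymethyl)propyl on an oxygen on a saturated carbon. Going by the values given here, the only measured step that touches the same oxygen is the one from compound 1 to compound 2, where adding the 3-hydroxy-2,2-bis(hydroxymethyl)propyl group left the number unmoved. Among the compounds with values here, that step removes the group now leaving; for the sulfo group that enters there is no step at all, so the expectation rests on the one observation that a large change on this oxygen did nothing beyond the scatter. Compound 3 is therefore expected to show a step of a 1.0-fold higher number from compound 2 to compound 3 (0.00 log units; within the scatter), with the estimate for compound 3 in this assay put at 12 uM, within a range of 4 uM to 40 uM.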

Compound 3, concentration for 50% inhibition: 5.6 uM
Compound 3: the middle estimate sits 2.1-fold (0.33 log units) above what was measured; low and high end bracket the measured number.
By their numbers in this assay, from the lowest: compound 3; then compounds 2 and 1 (each within the scatter of the next).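

Going by these compounds alone, the oxygen on a saturated carbon is not indifferent to every group in this assay: sulfo gives the first step beyond the scatter (with a 2.1-fold lower number from compound 2 to compound 3 (0.33 log units; beyond the scatter)), and the step against hydrogen on that oxygen has the same size (with a 2.1-fold lower number from compound 1 to compound 3 (0.33 log units; beyond the scatter)). The earlier flat step therefore holds for 3-hydroxy-2,2-bis(hydroxymethyl)propyl but does not extend to sulfo, so the identity of the group on this oxygen can move the number, though so far only modestly. Nothing measured alongside these numbers accounts for this step.

The compounds shown leave open whether the step is particular to sulfo or would recur with another group on the same oxygen, such as a phosphono group, a carboxymethyl group or an aminoethyl group. They also leave open whether sulfo would give a step of the same size elsewhere on the shared core, or with a longer chain in place of either chain carried by compound 3.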